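Compound 2 to compound 4: a new amide aryl group

A few compounds are considered here, and "the series" means these few. Any claim that something is new, unique, unknown or untested is made for them only; others in the source may bear on it.

In a functional assay on A549 cells (Homo sapiens) for cytotoxicity, read by MTT assay, with a stated time of 72 h (on this read-out lower numbers stand for stronger inhibition and higher numbers for weaker inhibition), compound 2 (`COc1ccc(NC(=O)CN2CCN(c3nnc(Cc4ccccc4)c4ccccc34)CC2)cc1OC`) is reported as "not active" (no number reported), so it has no number, while compound 1 (`COc1ccc(NC(=O)CN2CCN(c3nnc(Cc4ccncc4)c4ccccc34)CC2)cc1OC`) gives 26500 nM and compound 3 (`O=C(CN1CCN(c2nnc(Cc3ccncc3)c3ccccc23)CC1)Nc1cc(C(F)(F)F)ccc1Cl`) gives 1850 nM. Compound 4 (`O=C(CN1CCN(c2nnc(Cc3ccccc3)c3ccccc23)CC1)Nc1cccc(F)c1`) departs from compound 2 by 3-fluorophenyl in place of 3,4-dimethoxyphenyl on an amide-type nitrogen, with 3-fluorophenyl in place of 3,4-dimethoxyphenyl on an amide-type nitrogen. Among the compounds with values here, only one measured step bears on this: a 14-fold lower number from compound 1 to compound 3 (1.16 log units; beyond the scatter). It also removes 3,4-dimethoxyphenyl, and it is large. However, its entering group is different and its core is not that of compound 2, so only part of it is expected to carry over, in the same downward direction. For compound 4, the expected value in this assay is 15000 nM, with an estimated range of 3000 nM to 60000 nM.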

Compound 4, half-maximal inhibitory concentration: 130000 nM
Compound 4: middle estimate off by 8.7-fold (0.94 log units), on the low side; the measured number lies above the stated range.
By their numbers in this assay, from the lowest: compound 3; then compound 1; then compound 4.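

In this assay, within the data shown here, compound 2 has no number, so no step from it to compound 4 can be read. On these data alone, whether 3-fluorophenyl in place of 3,4-dimethoxyphenyl raises or lowers the number on the core of compound 2 stays open. No measurement shown offers an explanation for the value of compound 4.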